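Replacing a nitrile-bearing ring with a methylsulfonyl-bearing ring

The source may report more compounds than this note shows. Statements on the series, on what has been measured and on what is new or still open speak of the compounds shown alone.

Measured so far:
Compound 1 `C[C@H](Nc1nc(N)nc(N)c1C#N)c1nn(-c2cccc(S(C)(=O)=O)c2)c2cc(F)ccc12` gives 36% in a functional assay on Hep 3B2 cells (Homo sapiens) for inhibition, read by sulforhodamine B assay, with a stated time of 72 h, tested at 10 uM; on this read-out lower numbers stand for less inhibition and higher numbers for more inhibition at the one concentration tested (going by the name of the read-out).
Compound 2 `C[C@H](Nc1ncnc2[nH]cnc12)c1nn(-c2cccnc2)c2cc(F)ccc12` gives 20% in this assay.
Compound 3 `C[C@H](Nc1ncnc2[nH]cnc12)c1nn(-c2ccc(C#N)cc2)c2cc(F)ccc12` gives 46% in this assay.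

Compound 3 stands highest of the three, though its gap to compound 1 is within the scatter; only compound 2 lies clearly lower, as the step of a number 26 percentage points higher from compound 2 to compound 3 (beyond the scatter) shows. Compound 4 `C[C@H](Nc1ncnc2[nH]cnc12)c1nn(-c2cccc(S(C)(=O)=O)c2)c2cc(F)ccc12` differs from compound 3 by 3-(methylsulfonyl)phenyl in place of 4-cyanophenyl on an aromatic nitrogen. Among the measured compounds shown here, no measured step covers this exact change. Compound 1 carries the same 3-(methylsulfonyl)phenyl on a different core and gives 36%, a value within the scatter of compound 3, so no step beyond the scatter is expected. Compound 4 is therefore estimated at 38%, within 18% to 58%, an expected step of a number 8 percentage points lower from compound 3 to compound 4 (within the scatter).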

Compound 4, a percentage reported as inhibition, at one concentration (the size of the read-out at that concentration, not a potency): 11%
For compound 4 the middle estimate is 27 percentage points above the measured one; measured number below the stated range.
By their numbers in this assay, from the lowest: compounds 4 and 2 (each within the scatter of the next); then compounds 1 and 3 (each within the scatter of the next).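

At the aromatic nitrogen of the shared core, this assay shows that 3-(methylsulfonyl)phenyl in place of 4-cyanophenyl brings a number 35 percentage points lower from compound 3 to compound 4 (beyond the scatter), whereas the same group in place of pyridin-3-yl brings a number 9 percentage points lower from compound 2 to compound 4 (within the scatter). With 3-(methylsulfonyl)phenyl held constant, changing the group on the amine nitrogen brings a number 25 percentage points lower from compound 1 to compound 4 (beyond the scatter), so the aryl group does not set the read-out alone. No evidence here explains these differences. Still open, going by these compounds, is whether the nitrile or the ring position carries the step; 3-cyanophenyl and 4-(methylsulfonyl)phenyl would separate the two.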